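Chloro for Hydrogen on a Shared Core, Measured Twice

A few compounds are considered here, and "the series" means these few. Any claim that something is new, unique, unknown or untested is made for them only; others in the source may bear on it.

Of the compounds shown here, three have been measured in a functional assay on SF-539 cells (Homo sapiens) for cytotoxicity, read by sulforhodamine B assay, with a stated time of 48 h (a higher number here means a weaker inhibitor of growth, a lower number a stronger inhibitor of growth), and a fourth awaits its number. Compound 1 `ClCc1ccccc1Cn1cnc2c(Cl)nc(Cl)nc21` gives 1470 nM in this assay. Compound 2 `ClCc1ccccc1Cn1cnc2c(Cl)ncnc21` gives 10700 nM, and compound 3 `ClCc1cccc(Cn2cnc3ncnc(Cl)c32)c1` gives 20000 nM. Compound 3 and compound 2 share the same atoms joined differently; the difference between their two cores is not broken down here.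

Compound 2 and compound 1 differ in one place: chloro in place of hydrogen on an aromatic carbon. That change made a step of a 7.3-fold lower number from compound 2 to compound 1 (0.86 log units; beyond the scatter) in this assay.

Compound 4 `ClCc1cccc(Cn2cnc3nc(Cl)nc(Cl)c32)c1` has not been measured. It differs from compound 3 in one place: chloro in place of hydrogen on an aromatic carbon. The place of this change is described in the same words as the place of the change from compound 2 to compound 1, so it is the same change, made on a core that is arranged differently.

Only one measured instance of the change exists, so how far it carries over from the core of compound 2 to the core of compound 3 is not shown by the data. Resting on the step of a 7.3-fold lower number from compound 2 to compound 1 (0.86 log units; beyond the scatter), compound 4 is expected to stand at a 7.4-fold lower number from compound 3 to compound 4 (0.87 log units; beyond the scatter) from compound 3 in this assay. Compound 4 is therefore estimated at 2700 nM in this assay, with a likely range from 1000 nM to 8000 nM.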

Compound 4, concentration for 50% growth inhibition: 160 nM
Beside the measured number, compound 4's estimate is 17-fold (1.23 log units) above it, and the stated range ends above it.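

In this assay, chloro in place of hydrogen on an aromatic carbon gave a 130-fold lower number from compound 3 to compound 4 (2.10 log units; beyond the scatter), so the change lowered the number on both cores, though not by a similar amount: the same change on two cores in this assay, a 7.3-fold lower number (0.86 log units; beyond the scatter) from compound 2 to compound 1 and a 130-fold lower number (2.10 log units; beyond the scatter) from compound 3 to compound 4, 17-fold (1.23 log units) apart, beyond the scatter of two such steps

Across these two pairs, the direction of the change carried over from the core of compound 2 to the core of compound 3, but its size did not, so the step on one core gave no reliable measure of the step on the other. Going by these compounds alone, with only two pairs, this shows no general rule for other cores, and the numbers do not reveal which feature of the two differently arranged cores goes with the larger step.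

The compounds shown leave open whether an amine, a methoxy group or a longer chain on the same aromatic carbon, between two ring nitrogen atoms, would also give steps that differ between the two cores. Because every compound shown keeps its chloromethyl group, it also remains open how the chloro step would behave on either core with a hydroxymethyl group in its place.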